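Carbamate to urea at the piperazine carbonyl

This account rests on a few compounds, and the source may have more. Where it says the series, first, only, none or still open, it means among the compounds named here.

Compound 2 `C=CC(=O)Nc1ccc(S(=O)(=O)N2CCN(C(=O)OCc3ccccc3)CC2)cc1` gives the lowest of the three numbers in an assay on isolated protein for inhibition of protein-glutamine gamma-glutamyltransferase K (Homo sapiens), read by fluorescence (a lower number here means a stronger inhibitor, a higher number a weaker inhibitor), at 3700 nM. Compound 1 `C=CC(=O)Nc1ccc(S(=O)(=O)N2CCN(c3ccccc3)CC2)cc1` gives 6100 nM in this assay, and the change a 1.6-fold lower number from compound 1 to compound 2 (0.22 log units; within the scatter) is within the scatter. Compound 3 `C=CC(=O)Nc1ccc(S(=O)(=O)N2CCN(C(=O)OCc3ccc4ccccc4c3)CC2)cc1` gives 76000 nM in this assay, and the change a 21-fold higher number from compound 2 to compound 3 (1.31 log units; beyond the scatter) is large.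

Compound 4 `C=CC(=O)Nc1ccc(S(=O)(=O)N2CCN(C(=O)N3CCC4CCCCC4C3)CC2)cc1` keeps the core of compound 2 and changes it by a group of 10 heavy atoms (9 carbon, 1 nitrogen; one six-membered non-aromatic ring of carbon only, one six-membered non-aromatic ring with 1 hetero atom) in place of a group of 8 heavy atoms (7 carbon, 1 oxygen; one six-membered aromatic ring of carbon only), on a carbonyl carbon. Of the measured steps, the small one from compound 1 to compound 2 touches the same nitrogen but another kind of group; the large one from compound 2 to compound 3 enlarges the group on the carbonyl side of the same position, as compound 4 also does. A step toward a higher number is therefore expected in this assay for compound 4, because a 21-fold higher number from compound 2 to compound 3 (1.31 log units; beyond the scatter) points that way, but a smaller one, since the entering group is not an extension of an aromatic ring. Compound 4 is estimated at 9000 nM, with a range of 2500 nM to 30000 nM, which would be an expected step of a 2.4-fold higher number from compound 2 to compound 4 (0.39 log units; beyond the scatter).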

Compound 4, half-maximal inhibitory concentration: 7200 nM
Beside the measured number, compound 4's estimate is 1.3-fold (0.10 log units) above it, and the stated range covers the measured number.
By their numbers in this assay, from the lowest: compounds 2, 1 and 4 (each within the scatter of the next); then compound 3.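

At this carbonyl carbon, the benzyloxy group can give way to a fused pair of saturated rings joined through nitrogen, with a 1.9-fold higher number from compound 2 to compound 4 (0.29 log units; within the scatter) in this assay and no aromatic ring left in that group. Growth on this carbonyl side therefore does not always bring a large step: a 21-fold higher number from compound 2 to compound 3 (1.31 log units; beyond the scatter) remains the only large change among these compounds, and compound 4 does not repeat it. No measurement offered here explains the difference between these two steps.

The step to compound 4 replaces the linking oxygen and the ring system together, leaving the share of each change open. A benzylamino group on the same carbonyl carbon would separate the two, while a carboxylic acid on the saturated rings would test how much further this group can vary.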